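Hydroxy to methoxy: the step from compound 1 to compound 4

The compounds below may be only part of what the source reports. "The series", "measured", "known", "first", "only" and "open" are said of these compounds alone.

Three compounds were measured in an ADME assay on HEK293 cells (Homo sapiens) for cytotoxicity, read by resazurin assay, with a stated time of 48 h; on this read-out lower numbers stand for higher toxicity in this test and higher numbers for lower toxicity in this test:
compound 1 `O=S(=O)(Nc1ccc2oc(-c3ccccc3)nc2c1)c1ccccc1O` gives 33000 nM;
compound 2 `Cc1ccccc1S(=O)(=O)Nc1ccc(-c2nc3ccccc3o2)cc1` reaches only a limit of the assay, > 100000 nM;
compound 3 `CS(=O)(=O)Nc1ccc(-c2nc3ccccc3o2)cc1` likewise reaches only a limit, > 100000 nM.

Within the data shown here, compound 1 thus stands at the only true number in the set, while (the limit of > 100000 nM in this assay, at which 2 of the 3 values shown sit). The step that the two limits leave unreadable from compound 2 to compound 3 cannot be read, since both its ends are limits. Compound 4 `COc1ccccc1S(=O)(=O)Nc1ccc2oc(-c3ccccc3)nc2c1` differs from compound 1 by methyl in place of hydrogen on an oxygen on an aromatic ring. Among the measured compounds shown here, no measured step shares this change, so no direction can be drawn from the numbers. Compound 4 is therefore expected to remain close to compound 1, at an estimated 45000 nM (range 15000 nM to 130000 nM), a step of a 1.4-fold higher number from compound 1 to compound 4 (0.13 log units; within the scatter) that is expected to lie within the scatter.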

Compound 4, half-maximal cytotoxic concentration: 41000 nM
Compound 4: the middle estimate sits 1.1-fold (0.04 log units) above what was measured; the range from low to high includes it.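

In this assay, methyl in place of hydrogen on this oxygen gives a 1.2-fold higher number from compound 1 to compound 4 (0.09 log units; within the scatter), so compound 1 and compound 4 cannot be told apart on this read-out. Both ends of this step are true numbers, which makes it the first change in the set whose size can be read, while the other step cannot be read: the limit of > 100000 nM in this assay, at which 2 of the 4 values shown sit.

Still open, going by these compounds, is whether a longer chain on this oxygen, such as ethyl or propyl, would also stay this close to compound 1. On these data alone, an amine in place of the hydroxy group remains equally open.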